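This account rests on a few compounds, and the source may have more. Where it says the series, first, only, none or still open, it means among the compounds named here.

Working notes on the series. In a functional assay on HeLa cells (Homo sapiens) for inhibition, with a stated time of 72 h (on this read-out lower numbers stand for an effect already at smaller amounts and higher numbers for an effect only at larger amounts of compound), compound 1 `COc1cc(CNCc2ccncc2)ccc1OCc1ccccc1F` gives 5100 nM and compound 2 `COc1cc(CNCc2ccncc2)ccc1OCc1ccc(C(F)(F)F)cc1` gives 2400 nM as the lower of the two numbers, a gap that lies beyond the scatter. Compound 3 `COc1cc(CNCc2ccncc2)ccc1OCc1ccc(C)cc1` has not yet been measured. It keeps the shared core and carries methyl in place of trifluoromethyl on an aromatic carbon, para to a large group (methyl in place of trifluoromethyl on an aromatic carbon). Among the compounds with values here, no measured pair isolates this change. With compound 2 at 2400 nM and compound 1 at 5100 nM as the only anchors, the expectation stays close to those numbers. Expected in this assay is a small move toward a higher number, a 1.5-fold higher number from compound 2 to compound 3 (0.16 log units; within the scatter), possibly not beyond the scatter. The estimate for compound 3 is 3500 nM with an expected range of 1500 nM to 8000 nM for the coming measurement.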

Compound 3, half-maximal effective concentration: 5000 nM
The estimate for compound 3 lay 1.4-fold (0.15 log units) below the measured number, and the stated range covers the measured number.
By their numbers in this assay, from the lowest: compound 2; then compounds 3 and 1 (each within the scatter of the next).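

In this assay, within the data shown here, methyl in place of trifluoromethyl on an aromatic carbon, para to a large group, gives a 2.1-fold higher number from compound 2 to compound 3 (0.32 log units; beyond the scatter) as the first reading of a change in one place at this position, so the number does respond to this exchange. The second reading, a 1.0-fold lower number from compound 1 to compound 3 (0.01 log units; within the scatter) with 4-methylphenyl in place of 2-fluorophenyl, shows no separation between those two compounds, and of the three only compound 2 stands apart from the others. Nothing on hand gives a reason for either step. The compounds shown leave open whether a chlorine, a methoxy or a nitrile at this same place would stay with compound 2 or with compound 3. They also leave open whether a single fluorine there would do the same.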